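The source may hold more compounds than are shown below. What is called first, only, known or untested is meant among the compounds shown, and "the series" means these compounds.

Compound 1 `COc1ccc([C@H]2CC(=O)N(Cc3cccc(C#N)c3)C2)cc1OC1CCCC1` in a functional assay on HEK293 cells (Homo sapiens) for cytotoxicity (a lower number here means that less compound is tolerated, a higher number that more compound is tolerated), gives > 10000 nM, a limit of the measurement.
Compound 2 `COc1ccc([C@H]2CC(=O)N(c3ccc(N)cc3)C2)cc1OC1CCCC1` in this assay gives > 10000 nM, likewise only a limit.
Compound 3 `COc1ccc(S(=O)(=O)Nc2cccc(N3C[C@@H](c4ccc(OC)c(OC5CCCC5)c4)CC3=O)c2)cc1` in this assay gives > 10000 nM, again a limit rather than a number.

Going by the values given here, compound 3 therefore stands where every value so far stands: the limit of > 10000 nM in this assay, at which 3 of the 3 values shown sit. Among the compounds with values here, no compound has given a readable number, and the one change between measured compounds, a step that the two limits leave unreadable from compound 1 to compound 2, cannot be sized for the same reason.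

Compound 4 `COc1ccc([C@H]2CC(=O)N(c3cccc(NS(=O)(=O)c4cccc(Br)c4)c3)C2)cc1OC1CCCC1` has not yet been measured. It differs from compound 3 in one place: 3-bromophenyl in place of 4-methoxyphenyl on a sulfonyl sulfur. Within the data shown here, no measured change touches the group on the sulfonyl sulfur, so there is no step in the data that speaks directly to this change. What is known is that compound 3 sits at the limit and that the two further values sit there too, because of the limit of > 10000 nM in this assay, at which 3 of the 3 values shown sit.

On that basis the expectation for compound 4 is that the change from compound 3 will leave it at or near the limit, with a step that the limit leaves unreadable from compound 3 to compound 4 meaning no movement that can be read. The estimate for compound 4 in this assay is 15000 nM, expected to lie between 6000 nM and 40000 nM, and most likely to be reported again only as a limit.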

Compound 4, half-maximal cytotoxic concentration: > 10000 nM
Compound 4: no number, only a limit; the forecaster's own chance of this, stated with the estimate: 80%; the middle value does not contradict the limit.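

In this assay compound 4 gives > 10000 nM, a limit and not a number. No step from compound 3 to compound 4 can therefore be read, as both compounds rest at the same limit: the limit of > 10000 nM in this assay, at which 4 of the 4 values shown sit.

The compounds shown leave open at what concentration any of them would give a readable value, and whether the group on the sulfonyl sulfur makes any difference to it.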